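Truncating the alkyl chain on the core of compound 1

This account rests on a few compounds, and the source may have more. Where it says the series, first, only, none or still open, it means among the compounds named here.

Compound 1 `CCCc1nc2c(-c3ccccc3)cc(-c3ccccc3)nc2[nH]1` is the weaker of the two measured compounds in an assay on CHO cells for displacement of a labelled ligand from adenosine receptor A1 (Homo sapiens) (a higher number here means a weaker inhibitor, a lower number a stronger inhibitor), where compound 1 gives 2.5 nM; this is the highest of the two numbers. Compound 2 `CC(C)Cc1nc2c(-c3ccccc3)cc(-c3ccccc3)nc2[nH]1` gives 0.55 nM in this assay. Among the measured compounds shown here, the only measured step, a 4.5-fold lower number from compound 1 to compound 2 (0.66 log units; beyond the scatter), adds a methyl on a saturated chain carbon bound to two saturated chain carbons and lowers the number beyond the scatter.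

Compound 3 `Cc1nc2c(-c3ccccc3)cc(-c3ccccc3)nc2[nH]1` differs from compound 1 by hydrogen in place of ethyl on a saturated chain carbon bound to an aromatic carbon; seen one bond further out, propyl becomes methyl. For the measured compounds named here, no step of exactly this kind has been measured. Going by the values given here, the one step available runs the other way, enlarging the chain and strengthening binding, and it sits at a different place on the chain, so it bears on the present change only as a direction: shortening the chain is expected to raise the number. With compound 1 at 2.5 nM as the anchor, a modest step of a 3.2-fold higher number from compound 1 to compound 3 (0.51 log units; beyond the scatter) is expected for compound 3, and its value in this assay is estimated at 8 nM, between 2.5 nM and 25 nM.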

Compound 3, inhibition constant: 14 nM
Compound 3: middle estimate off by 1.8-fold (0.24 log units), on the low side; low and high end bracket the measured number.
By their numbers in this assay, from the lowest: compound 2; then compound 1; then compound 3.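

In this assay, the change from propyl to methyl on the saturated chain carbon bound to an aromatic carbon gives a 5.6-fold higher number from compound 1 to compound 3 (0.75 log units; beyond the scatter) and so supplies the first measured loss from shortening this chain, where the earlier step showed only a gain from enlarging it. Replacing the branched chain of compound 2 by methyl gives a 25-fold higher number from compound 2 to compound 3 (1.41 log units; beyond the scatter) and is the largest step among these compounds, which shows that this position tolerates a wide change in the number while the shared core stays the same. Across compound 3, compound 1 and compound 2, each addition of saturated carbon to the chain goes with a lower number, and none of the three goes against this order, though the pattern rests on these compounds alone.

Still open, going by these compounds, is whether the order continues to a longer chain such as pentyl, and whether it survives a ring such as cyclopentyl or a chain ending in an amine or a hydroxyl. Nothing shown gives a reason for the movement of the number with the chain.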